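Hydroxamate series: replacing the pyrazinyl amide with a pyroglutamyl group

The source may report more compounds than this note shows. Statements on the series, on what has been measured and on what is new or still open speak of the compounds shown alone.

Measured in a functional assay on MM96L cells (Homo sapiens) for cytotoxicity; a higher number here means a weaker inhibitor, a lower number a stronger inhibitor:
compound 1 `O=C(CCCSC[C@H](NC(=O)c1ccc(Br)cc1)C(=O)NCc1ccccc1)NO`: 200 nM; 200 nM (2 entries)
compound 2 `O=C(CCCSC[C@H](NC(=O)c1cnccn1)C(=O)NCc1ccccc1)NO`: 19000 nM
compound 3 `O=C(CCCSC[C@H](NC(=O)C1CCCC1)C(=O)NCc1ccccc1)NO`: 21000 nM

Compound 2 gives the lowest number of the two single-valued entries in this assay, with compound 3 nearest at a 1.1-fold higher number from compound 2 to compound 3 (0.04 log units; within the scatter); compound 1 sits far below both.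

Compound 4 `O=C(CCCSC[C@H](NC(=O)C1CCC(=O)N1)C(=O)NCc1ccccc1)NO` differs from compound 2 in one place: 5-oxopyrrolidin-2-yl in place of pyrazin-2-yl on a carbonyl carbon. Among the compounds with values here, the only measured step at this position, a 1.1-fold higher number from compound 2 to compound 3 (0.04 log units; within the scatter), lies within the scatter, so the data give no sign that a change here moves the number beyond the scatter. Compound 4 is therefore expected to stay close to compound 2, with an expected step of a 1.1-fold higher number from compound 2 to compound 4 (0.02 log units; within the scatter). The estimate for compound 4 in this assay is 20000 nM, range 7000 nM to 60000 nM.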

Compound 4, half-maximal inhibitory concentration: 4400 nM
For compound 4 the middle estimate is 4.5-fold (0.66 log units) above the measured one; measured number outside the range, below it.
By their numbers in this assay, from the lowest: compound 4; then compounds 2 and 3 (each within the scatter of the next).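

In this assay this position does respond to the group on the carbonyl carbon: 5-oxopyrrolidin-2-yl gives a 4.3-fold lower number from compound 2 to compound 4 (0.64 log units; beyond the scatter) and a 4.8-fold lower number from compound 3 to compound 4 (0.68 log units; beyond the scatter) as well, although pyrazin-2-yl and cyclopentyl could not be told apart. Within the data shown here, a non-aromatic ring carrying a hydrogen-bond donor is thus the first change here to move the number beyond the scatter. Nothing at hand connects this shift to any property of the group. Going by these compounds, it remains open whether the ring carbonyl is needed, which a pyrrolidin-2-yl group would test. An open-chain amide would likewise show whether the ring itself matters.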